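The source may report more compounds than this note shows. Statements on the series, on what has been measured and on what is new or still open speak of the compounds shown alone.

Measured so far in an ADME assay on MDCK cells (Canis lupus familiaris) for cytotoxicity; on this read-out higher numbers stand for lower toxicity in this test and lower numbers for higher toxicity in this test:

compound 1, `CN(C(=O)C1(c2ccccc2)CCCC1)c1cccc(Cl)c1`, gives 17000 nM
compound 2, `CN(C(=O)C1(c2ccccc2)CCCC1)c1cccc(C#N)c1`, gives 56000 nM
compound 3, `CN(C(=O)C1(c2ccccc2)CCCC1)c1ccc(Cl)cc1`, gives 20000 nM

The change cyano in place of chloro on an aromatic carbon produced a 3.3-fold higher number from compound 1 to compound 2 (0.52 log units; beyond the scatter). Compounds 1 and 3 differ only in their cores, namely (4-chlorophenyl in place of 3-chlorophenyl on an amide-type nitrogen), which produced a 1.2-fold higher number from compound 1 to compound 3 (0.07 log units; within the scatter). Compound 4, `CN(C(=O)C1(c2ccccc2)CCCC1)c1ccc(C#N)cc1`, is not yet measured; it differs from compound 3 by cyano in place of chloro on an aromatic carbon. Going by the values given here, this is the same kind of change as the one between compound 1 and compound 2, but not the same: there the entering group sat meta to a large group, here it sits para to a large group. In this assay a step of about a 2.8-fold higher number from compound 3 to compound 4 (0.44 log units; beyond the scatter) is expected, because the same kind of change gave a 3.3-fold higher number from compound 1 to compound 2 (0.52 log units; beyond the scatter). Compound 4 is therefore estimated at 55000 nM, most likely between 22000 nM and 140000 nM.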

Compound 4, half-maximal cytotoxic concentration: > 100000 nM
Compound 4: a limit, no number (the forecaster's own chance of this, stated with the estimate: 20%); at least 1.8-fold (0.25 log units) between middle value and limit.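

In this assay compound 4 gives > 100000 nM, which is a limit of the assay and not a number. Cyano in place of chloro on an aromatic carbon gives an at least 5.0-fold higher number from compound 3 to compound 4 (0.69 log units; beyond the scatter), so the number goes up on both cores, and the direction of the change carries over: the same change on two cores in this assay, a 3.3-fold higher number (0.52 log units; beyond the scatter) from compound 1 to compound 2 and an at least 5.0-fold higher number (0.69 log units; beyond the scatter) from compound 3 to compound 4; the limit leaves it open whether they differ The size of the step on the core of compound 3 stays unknown, so these data cannot show whether the change carries over with the same size: the limit of > 100000 nM in this assay, at which 1 of the 4 values shown sits.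

The compounds shown leave open whether an amine or a carboxylic acid in place of chloro would also give a higher number. They also leave open whether the cyano step holds on any core beyond these two.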